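From Chloro to Iodo at the Assay Limit

The source may hold more compounds than are shown below. What is called first, only, known or untested is meant among the compounds shown, and "the series" means these compounds.

In a functional assay on MDA-MB-231 cells (Homo sapiens) for cytotoxicity, read by MTT assay, with a stated time of 48 h (on this read-out higher numbers stand for weaker inhibition and lower numbers for stronger inhibition), compound 1 (`O=C(NCCCCC(c1ccc(F)cc1)c1ccc(F)cc1)Nc1ccc(Cl)cc1C(F)(F)F`) gives > 20000 nM as a limit of the assay and not a number. Compound 2 (`COC(=O)c1ccc(NC(=O)NCCCCC(c2ccc(F)cc2)c2ccc(F)cc2)cc1C(F)(F)F`) gives 4430 nM as a true measured number. Compound 3 (`O=C(NCCCCN(c1ccc(F)cc1)c1ccc(F)cc1)Nc1ccc(Cl)cc1`) gives > 20000 nM as another limit, so it has no exact place on the scale. Compound 3 therefore stands at the end of what can be read (the limit of > 20000 nM in this assay, at which 2 of the 3 values shown sit) and offers no exact starting point.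

Compound 4 (`O=C(NCCCCN(c1ccc(F)cc1)c1ccc(F)cc1)Nc1ccc(I)cc1`) differs from compound 3 in one place (iodo in place of chloro on an aromatic carbon): iodo in place of chloro on an aromatic carbon, para to a large group. Among the compounds with values here, no pair of tested compounds differs by a single change, so no measured step can guide the expectation. Compound 3 reads > 20000 nM as a limit and the swap touches a single atom, so no step beyond the usual scatter is expected in this assay and a second limit is quite possible. The estimated change is an at least 1.1-fold lower number from compound 3 to compound 4 (0.04 log units; that floor lies within the scatter) and it cannot be placed more closely from these data. For compound 4 the expected value is 18000 nM with an estimated range from 7000 nM to 40000 nM for repeated measurements.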

Compound 4, half-maximal inhibitory concentration: > 20000 nM
Compound 4: no number, only a limit (the forecaster's own chance of this, stated with the estimate: 60%); middle value at least 1.1-fold (0.04 log units) away from the limit.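

Compound 3 and compound 4 both end at a limit and not at a number in this assay, so no step can be read for iodo in place of chloro: the limit of > 20000 nM in this assay, at which 3 of the 4 values shown sit.

The compounds shown leave open whether this swap changes the reading at all, and where on the scale either compound would truly fall.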